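Swapping a cyclopropyl thioester for a chloropyrimidine amide

This account rests on a few compounds, and the source may have more. Where it says the series, first, only, none or still open, it means among the compounds named here.

Compound 3 `Cc1nc(S(C)(=O)=O)ccc1Oc1ncnc(OC2CCN(C(=O)SC3(C)CC3)CC2)c1F` gives 13.2 nM in a functional assay on isolated protein for inhibition of Glucose-dependent insulinotropic receptor (Homo sapiens), read by HTRF and cAMP accumulation; on this read-out higher numbers stand for an effect only at larger amounts of compound and lower numbers for an effect already at smaller amounts. It holds the lowest of the three numbers, but compound 2 `Cc1nc(S(C)(=O)=O)ccc1Oc1ncnc(OC2CCN(C(=O)OC3(C(F)(F)F)CCC3)CC2)c1F`, at 14.3 nM, lies within the scatter of it, so the two cannot be ranked; only compound 1 `Cc1nc(S(C)(=O)=O)ccc1Oc1ncnc(OC2CCN(C(=O)OC3COC3)CC2)c1F`, at 326 nM, stands clearly apart, with a 25-fold lower number from compound 1 to compound 3 (1.39 log units; beyond the scatter) and a 23-fold lower number from compound 1 to compound 2 (1.36 log units; beyond the scatter). Compound 4 `Cc1nc(S(C)(=O)=O)ccc1Oc1ncnc(OC2CCN(C(=O)c3ncc(Cl)cn3)CC2)c1F` alters the group on the carbonyl carbon: a group of 7 heavy atoms (4 carbon, 2 nitrogen, 1 chlorine; one six-membered aromatic ring with 2 hetero atoms) in place of a group of 5 heavy atoms (4 carbon, 1 sulfur; one three-membered non-aromatic ring of carbon only), on a carbonyl carbon. Both earlier steps at that carbonyl carbon bear on this, yet neither placed an aromatic ring there, so the guide is loose. Given a 1.1-fold lower number from compound 2 to compound 3 (0.03 log units; within the scatter), a number near compound 3 seems most likely, with the change to compound 4 expected to be a 2.3-fold higher number from compound 3 to compound 4 (0.36 log units; beyond the scatter). Compound 4 is therefore expected to give 30 nM, in the range 8 nM to 150 nM.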

Compound 4, half-maximal effective concentration: 6.12 nM
Beside the measured number, compound 4's estimate is 4.9-fold (0.69 log units) above it; the measured number lies below the stated range.
By their numbers in this assay, from the lowest: compound 4; then compounds 3 and 2 (each within the scatter of the next); then compound 1.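

At the carbonyl carbon, whose other neighbour is an amide-type nitrogen in a ring, 5-chloropyrimidin-2-yl brings the first aromatic ring to this position, and in this assay it does better than the earlier groups, with a 2.2-fold lower number from compound 3 to compound 4 (0.33 log units; beyond the scatter) and a 2.3-fold lower number from compound 2 to compound 4 (0.37 log units; beyond the scatter) as modest steps and a 53-fold lower number from compound 1 to compound 4 (1.73 log units; beyond the scatter) as a large one. Nothing measured here explains this difference. Compound 4 is the only compound shown with an aromatic ring at this position, so the roles of its chlorine and ring nitrogens remain open. Comparing it with a 5-methylpyrimidin-2-yl or a plain phenyl group would begin to separate them.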